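A Hydroxy Group Lost, an Ethoxy Group Gained

The source may hold more compounds than are shown below. What is called first, only, known or untested is meant among the compounds shown, and "the series" means these compounds.

Of the compounds shown here, two sharing one core have been measured so far in a functional assay on HeLa cells (Homo sapiens) for antiproliferative activity, read by MTT assay, with a stated time of 48 h; on this read-out lower numbers stand for stronger inhibition and higher numbers for weaker inhibition. Here compound 1 `COc1ccc(-c2cc3c(cn2)[nH]c(=O)n3-c2cc(OC)c(OC)c(OC)c2)cc1F` gives 2210 nM, while compound 2 `COc1ccc(-c2cc3c(cn2)[nH]c(=O)n3-c2cc(OC)c(OC)c(OC)c2)cc1O` gives 490 nM, the lower of the two numbers and so the stronger result. The next compound to test is compound 3 `CCOc1ccc(-c2cc3c(cn2)[nH]c(=O)n3-c2cc(OC)c(OC)c(OC)c2)cc1`, and the change is 4-ethoxyphenyl in place of 3-hydroxy-4-methoxyphenyl on an aromatic carbon. Among the measured compounds shown here, only one measured step bears on this: hydroxy in place of fluoro on an aromatic carbon gave a 4.5-fold lower number from compound 1 to compound 2 (0.65 log units; beyond the scatter). For the measured compounds named here, it is a modest step and only a rough guide, since compound 3 carries neither hydroxy nor fluoro on that ring, and no measured compound carries ethoxy. Since compound 1 without the hydroxy group stands at 2210 nM, a return towards that higher number is expected. The expected change is a 4.1-fold higher number from compound 2 to compound 3 (0.61 log units; beyond the scatter), similar in size to the measured step but running towards weaker inhibition. For compound 3 the estimated value is 2000 nM, with an expected range from 600 nM to 7000 nM.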

Compound 3, half-maximal inhibitory concentration: 3730 nM
Compound 3: middle estimate off by 1.9-fold (0.27 log units), on the low side; low and high end bracket the measured number.
By their numbers in this assay, from the lowest: compound 2; then compounds 1 and 3 (each within the scatter of the next).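

In this assay, putting 4-ethoxyphenyl in place of 3-hydroxy-4-methoxyphenyl gives a 7.6-fold higher number from compound 2 to compound 3 (0.88 log units; beyond the scatter), so the lower number of compound 2 does not survive this change at this ring. Set against the fluoro-bearing ring, the same 4-ethoxyphenyl group gives a 1.7-fold higher number from compound 1 to compound 3 (0.23 log units; within the scatter), which means that compound 1 and compound 3 cannot be told apart here and that, among these three, only the ring carrying a hydroxy group stands clearly apart. Nothing available here explains this pattern.

The step from compound 2 to compound 3 changes two things at once, removing the hydroxy group and replacing methoxy with ethoxy, so the compounds shown cannot say how much of the rise belongs to each change. Going by these compounds, a 3-hydroxy-4-ethoxyphenyl ring would keep the hydroxy group alongside the ethoxy group, and an amine in place of the hydroxy group would test whether another group can stand in for it, so both remain open questions at this position.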